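Working notes: acetyl in place of ethoxy, compound 4

The compounds below may be only part of what the source reports. "The series", "measured", "known", "first", "only" and "open" are said of these compounds alone.

Measured so far, in a functional assay on the whole organism for inhibition, with Rattus norvegicus as the target; a higher number here means that more compound is needed for the effect, a lower number that less compound is needed:
compound 1 `CC1CC/C(=N\Nc2ccc(F)cc2)c2ncc(C(=O)O)c(=O)n21` gives 12.2 umol/kg
compound 2 `COc1ccc(N/N=C2\CCC(C)n3c2ncc(C(=O)O)c3=O)cc1` gives 0.8 umol/kg
compound 3 `CCOc1ccc(N/N=C2\CCC(C)n3c2ncc(C(=O)O)c3=O)cc1` gives 1.6 umol/kg

Compound 3 holds the second highest of the three numbers. Its nearest neighbour is compound 2: a 2.0-fold higher number from compound 2 to compound 3 (0.30 log units; within the scatter). Its furthest is compound 1: a 7.6-fold lower number from compound 1 to compound 3 (0.88 log units; beyond the scatter).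

Compound 4 `CC(=O)c1ccc(N/N=C2\CCC(C)n3c2ncc(C(=O)O)c3=O)cc1` differs from compound 3 in one place: acetyl in place of ethoxy on an aromatic carbon.

Among the compounds with values here, two steps touch the same aromatic carbon and both are large: a 15-fold lower number from compound 1 to compound 2 (1.18 log units; beyond the scatter) and a 7.6-fold lower number from compound 1 to compound 3 (0.88 log units; beyond the scatter). They show that the substituent on this carbon can move the number well beyond the scatter. The third step, a 2.0-fold higher number from compound 2 to compound 3 (0.30 log units; within the scatter), extends the alkoxy chain and stays within the scatter. Within the data shown here, no measured step exchanges an alkoxy for a carbonyl-bearing group, so the direction is not anchored by a direct precedent. Given that the group leaving and the group entering each carry one hydrogen-bond acceptor, yet the alkoxy-to-fluoro steps were large, a modest step toward a higher number is expected, with wide uncertainty in this assay: a 2.5-fold higher number from compound 3 to compound 4 (0.40 log units; beyond the scatter).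

Compound 4 is therefore estimated at 4 umol/kg, with a range from 1.2 umol/kg to 14 umol/kg.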

Compound 4, dose for 50% inhibition: 9.5 umol/kg
Compound 4: the middle estimate sits 2.4-fold (0.38 log units) below what was measured; low and high end bracket the measured number.
By their numbers in this assay, from the lowest: compounds 2 and 3 (each within the scatter of the next); then compounds 4 and 1 (each within the scatter of the next).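

In this assay, acetyl in place of ethoxy on this aromatic carbon, para to a large group, is not a neutral exchange, although the two groups count the same heavy atoms and hydrogen-bond acceptors: the change gives a 5.9-fold higher number from compound 3 to compound 4 (0.77 log units; beyond the scatter), and the matching change from methoxy gives a 12-fold higher number from compound 2 to compound 4 (1.07 log units; beyond the scatter). Acetyl does not stay with the alkoxy groups but falls with fluoro, with a 1.3-fold lower number from compound 1 to compound 4 (0.11 log units; within the scatter), so the four substituents on this carbon form two sets, methoxy and ethoxy at the low numbers and fluoro and acetyl at the high numbers, and none of the four compounds goes against this split. Nothing available here accounts for the split.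

Still open, going by these compounds, is where an amine, a hydroxyl or a nitrile on this carbon would fall relative to the two sets, and whether an alkoxy chain longer than ethoxy stays with methoxy and ethoxy. Also open, on these data alone, is whether the carbonyl of the acetyl group is what places compound 4 with compound 1, which a 1-hydroxyethyl group on the same carbon could help to show.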